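From pyridin-4-yl to pyridin-3-yl: an antiproliferative comparison

The source may report more compounds than this note shows. Statements on the series, on what has been measured and on what is new or still open speak of the compounds shown alone.

Compound 1 `O=C(N/N=C/c1cccnc1)c1cc2ccccc2oc1=O`: 9900 nM
Compound 2 `O=C(N/N=C/c1ccncc1)c1cc2cc([N+](=O)[O-])ccc2oc1=O`: 13000 nM

In a functional assay on CCRF-CEM cells (Homo sapiens) for antiproliferative activity, read by fluorescence and resazurin assay, with a stated time of 48 h (on this read-out lower numbers stand for stronger inhibition and higher numbers for weaker inhibition), compound 2 gives 13000 nM. For the measured compounds named here, that value lies within the usual scatter of the one for compound 1 at 9900 nM, so the two numbers cannot be told apart.

Compound 3 `O=C(N/N=C/c1cccnc1)c1cc2cc([N+](=O)[O-])ccc2oc1=O` has not yet been measured. It carries pyridin-3-yl in place of pyridin-4-yl on a carbon with a double bond to nitrogen.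

Going by the values given here, no measured pair shows this change on its own, so the data give no direct size for it. In this assay no step beyond the scatter is expected, and neither direction is favoured. The expectation is anchored on compound 2 at 13000 nM. The expected change is a 1.1-fold lower number from compound 2 to compound 3 (0.03 log units; within the scatter). Compound 3 is estimated at 12000 nM, with an expected range of 5500 nM to 26000 nM.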

Compound 3, half-maximal inhibitory concentration: 17100 nM
Estimate against measurement, compound 3: 1.4-fold (0.15 log units) below; the range from low to high includes it.
By their numbers in this assay, from the lowest: compounds 1, 2 and 3 (each within the scatter of the next).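

In this assay, for the compounds shown here, pyridin-3-yl in place of pyridin-4-yl on a carbon with a double bond to nitrogen gives a 1.3-fold higher number from compound 2 to compound 3 (0.12 log units; within the scatter), the first direct reading of this change, and it does not tell the two groups apart. The same result supplies a second single-place reading: nitro in place of hydrogen on an aromatic carbon gives a 1.7-fold higher number from compound 1 to compound 3 (0.24 log units; within the scatter), so this change cannot be told from no change either. Nothing available bears on the cause of either step.

From the compounds shown here alone, each change is read only once, on a single background, so it remains open whether either would behave the same elsewhere on the shared core. Going by these compounds, it is also open whether a phenyl ring in place of the pyridin-3-yl, or an amine in place of the nitro, would move the number beyond the scatter.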